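The compounds below may be only part of what the source reports. "The series", "measured", "known", "first", "only" and "open" are said of these compounds alone.

Measured so far:
compound 1, `CCCN(CCC)c1cc(C)nc2c(-c3ccc(Cl)cn3)c(C)nn12`: 88 nM
compound 2, `CCCN(CCC)c1cc(C)nc2c(-c3ncc(N4CCCCC4)cc3C)c(C)nn12`: 17 nM

Both compounds were tested in an assay on isolated protein for binding affinity to corticotropin-releasing factor receptor 1 (Homo sapiens); a higher number here means a weaker inhibitor, a lower number a stronger inhibitor. Of the two numbers, compound 2 holds the lower one; the gap between compound 2 and compound 1 is beyond the usual scatter of this assay, so compound 2 is the stronger binder of the pair.

Compound 3, `CCCN(CCC)c1cc(C)nc2c(-c3ncc(N=O)cc3C)c(C)nn12`, has not yet been measured. It differs from compound 2 in one place: a group of 2 heavy atoms (1 nitrogen, 1 oxygen; no ring) in place of a group of 6 heavy atoms (5 carbon, 1 nitrogen; one six-membered non-aromatic ring with 1 hetero atom), on an aromatic carbon. Among the measured compounds shown here, no step between measured compounds matches this exact change, so its effect can only be gauged from what compound 1 and compound 2 show.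

The loss of the six-membered ring is expected to cost affinity, because compound 1, which also lacks the piperidin-1-yl, gives 88 nM. Compound 3 is therefore expected to show a step of a 4.1-fold higher number from compound 2 to compound 3 (0.61 log units; beyond the scatter) towards a weaker inhibitor, beyond the scatter. The estimate for compound 3 in this assay is 70 nM, with a range from 25 nM to 200 nM.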

Compound 3, inhibition constant: 100 nM
For compound 3 the middle estimate is 1.4-fold (0.15 log units) below the measured one; measured number inside the range.
By their numbers in this assay, from the lowest: compound 2; then compounds 1 and 3 (each within the scatter of the next).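

In this assay, among the compounds shown here, the exchange of the piperidin-1-yl for the group of 2 heavy atoms (1 nitrogen, 1 oxygen) gives a 5.9-fold higher number from compound 2 to compound 3 (0.77 log units; beyond the scatter) and is the first reading of a change on this aromatic carbon, two atoms from the ring nitrogen, with the methyl group held constant. The loss from this one change is therefore now measured directly, rather than inferred from compound 1, whose ring also differs in its methyl group and its chlorine. The replacement of the whole aromatic group gives a 1.1-fold higher number from compound 1 to compound 3 (0.06 log units; within the scatter) and leaves compound 3 and compound 1 indistinguishable in this assay, so among these three compounds only the one carrying the piperidin-1-yl stands apart.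

Nothing measured here explains why the number shifts with this change.

Going by these compounds, it remains open whether the six-membered ring itself matters or whether another nitrogen-linked group would serve equally well on this carbon, as a morpholin-4-yl, a dimethylamino group or a plain amine could show. The part played by the methyl group also stays unresolved, since a chlorine on this carbon appears here only in compound 1, which lacks that methyl group.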